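This account rests on a few compounds, and the source may have more. Where it says the series, first, only, none or still open, it means among the compounds named here.

Measured compounds in the series:
compound 1, `CC1(c2ccccc2)CC(=O)N(CC(=O)N2CCN(c3ccc(Cl)cc3)CC2)C1=O`: 300 mg/kg
compound 2, `CC1(c2ccccc2)CC(=O)N(CC(=O)N2CCN(c3cccc(Cl)c3)CC2)C1=O`: "not active" (no number reported)
compound 3, `CC1(c2ccccc2)CC(=O)N(CC(=O)N2CCN(c3cccc(Cl)c3Cl)CC2)C1=O`: "not active" (no number reported)

All three share one core and differ only in the aryl group on the amine nitrogen of the six-membered ring with two nitrogens. In a functional assay on the whole organism (strain CD-1) with Mus musculus as the target, with a stated time of 2 h (on this read-out higher numbers stand for an effect only at larger amounts of compound and lower numbers for an effect already at smaller amounts), compound 1 gives 300 mg/kg. In this assay compound 2 gives "not active" (no number reported), so no number stands for it. Compound 3 stands in the same position: in this assay compound 3 gives "not active" (no number reported), and no dose can be read off for it. With two of the three measured entries carrying no number, compound 1 is the only point in the series with a measured dose, and it sits at a high dose.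

Compound 4, `CC1(c2ccccc2)CC(=O)N(CC(=O)N2CCN(c3cccc(C(F)(F)F)c3)CC2)C1=O`, is not yet measured. The change from compound 3 is 3-(trifluoromethyl)phenyl in place of 2,3-dichlorophenyl on an amine nitrogen in a ring. Among the measured compounds shown here, no step between measured compounds is known for a change of this kind. Given that compound 2 and compound 3 gave no number, and compound 1 gave only a high dose, the expectation for compound 4 is either no reported number or a dose in the range of compound 1; no movement beyond the scatter in either direction can be supported. Compound 4 is estimated at 300 mg/kg, expected to fall between 100 mg/kg and 1000 mg/kg.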

Compound 4, minimum effective dose: "not active" (no number reported)
For compound 4 the study gives words and no number, so the estimate cannot be set against anything.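

Like compound 3, compound 4 is reported in this assay as "not active" (no number reported), so no step can be read between the two. No measured property bears on this result. The compounds shown leave open whether any aryl group on the amine nitrogen, other than that of compound 1, gives a numerical dose at all.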